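The source may hold more compounds than are shown below. What is called first, only, known or untested is meant among the compounds shown, and "the series" means these compounds.

Compound 1 `COc1ccc(-c2c3c(nn2C(C)C)CCNCC3)cc1` gives 18 nM
Compound 2 `CC(C)n1nc2c(c1-c1ccc(Cl)cc1)CCNCC2` gives 9 nM
Compound 3 `CNc1ccc(-c2c3c(nn2C(C)C)CCNCC3)cc1` gives 40 nM

For the measured compounds named here, the three compounds share one core and differ only in the single group on the phenyl ring. In an assay on HEK293 cells for displacement of a labelled ligand from 5-hydroxytryptamine receptor 7 (Rattus norvegicus), read by radioligand binding (a lower number here means a stronger inhibitor, a higher number a weaker inhibitor), compound 3 gives 40 nM, the highest of the three numbers. Both steps leading to it, a 2.2-fold higher number from compound 1 to compound 3 (0.35 log units; beyond the scatter) and a 4.4-fold higher number from compound 2 to compound 3 (0.65 log units; beyond the scatter), lie beyond the scatter, so compound 3 is the weakest inhibitor of the set; compound 1 and compound 2 are separated only by a 2.0-fold lower number from compound 1 to compound 2 (0.30 log units; within the scatter), which stays within the scatter.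

Compound 4 `CC(C)n1nc2c(c1-c1ccc(C(F)(F)F)cc1)CCNCC2` is reached from compound 3 by trifluoromethyl in place of methylamino on an aromatic carbon. The step that bears most directly on this change is a 4.4-fold higher number from compound 2 to compound 3 (0.65 log units; beyond the scatter), where methylamino replaced chloro and the number rose modestly; compound 2, carrying chloro, gives 9 nM. Replacing methylamino with trifluoromethyl is expected to undo much of that rise, so a modest fall is expected, a 3.3-fold lower number from compound 3 to compound 4 (0.52 log units; beyond the scatter). Compound 4 is therefore estimated at 12 nM, with a likely range from 5 nM to 35 nM.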

Compound 4, inhibition constant: 15 nM
Estimate against measurement, compound 4: 1.3-fold (0.10 log units) below; low and high end bracket the measured number.
By their numbers in this assay, from the lowest: compounds 2, 4 and 1 (each within the scatter of the next); then compound 3.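

In this assay, the change to trifluoromethyl (a 2.7-fold lower number from compound 3 to compound 4 (0.43 log units; beyond the scatter)) shows that the higher number of compound 3 is also lost with a third group, one of four heavy atoms with no hydrogen-bond donor or acceptor. That new group cannot be told apart from chloro (a 1.7-fold higher number from compound 2 to compound 4 (0.22 log units; within the scatter)) or from methoxy (a 1.2-fold lower number from compound 1 to compound 4 (0.08 log units; within the scatter)), so among the four groups at this position on the phenyl ring, only methylamino in compound 3 stands apart. Nothing measured here explains why methylamino differs from the other three.

Still open, from the compounds shown here alone, is whether a plain amine or a dimethylamino group would give a number as high as that of compound 3. Also open, going by these compounds, is how a carboxylic acid or a longer chain such as ethoxy would fare here.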